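Swapping a urea for a sulfonamide: stability outlook

The source may report more compounds than this note shows. Statements on the series, on what has been measured and on what is new or still open speak of the compounds shown alone.

Measured compounds:
- compound 1 `COc1cc(-c2c(C)nc3c(N4CC[C@@H](NC(C)=O)C4)cc(C)nn23)ccc1F` sits at the assay limit of > 95%
- compound 2 `COc1ccc(-c2c(C)nc3c(N4CC[C@@H](NC(C)=O)C4)cc(C)nn23)cc1F` sits at the assay limit of > 95%
- compound 3 `COc1ccc(-c2c(C)nc3c(N4CC[C@@H](NC(=O)NC(C)C)C4)cc(C)nn23)cc1OC` sits at the assay limit of > 95%

In an ADME assay on microsomes from liver (Mus musculus) for metabolic stability, read by LC-MS, with NADPH named in the record, with a stated time of 60 min, tested at 1 uM, in the absence of a further agent (a lower number here means that less of the compound is left, a higher number that more of the compound is left), every measured compound comes back as a limit rather than a number, so that the limit of > 95% in this assay, at which 3 of the 3 values shown sit, is all the data show. Within the data shown here, the one single-point step, a step that the two limits leave unreadable from compound 1 to compound 2, lies between two limits and cannot be read in size or direction. Compound 3 stands at the same limit as compound 1 and compound 2, with nothing in this assay to set it apart from them.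

Compound 4 `COc1ccc(-c2c(C)nc3c(N4CC[C@@H](NS(=O)(=O)c5ccc(Cl)cc5)C4)cc(C)nn23)cc1OC` differs from compound 3 in one place: (4-chlorophenyl)sulfonyl in place of isopropylcarbamoyl on an amine nitrogen. No measured step touches this change, and the only step shown is unreadable, so nothing in the shown data points to a move beyond the scatter in this assay. Compound 4 is therefore expected to stay near the limit, with an estimated 93% and a range from 80% to 99%. The expected step of a number at least 2 percentage points lower from compound 3 to compound 4 (that floor lies within the scatter) is judged to be within the scatter.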

Compound 4, percent of the compound remaining: > 95%
Compound 4 gave a limit, no number; the forecaster's own chance of this, stated with the estimate: 65%; middle value at least 2 percentage points away from the limit.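

Compound 3 and compound 4 each give only a limit, so the step between them cannot be read in size or direction, and the data show just this: the limit of > 95% in this assay, at which 4 of the 4 values shown sit.

From the compounds shown here alone, what stays open is how far these compounds would differ in this assay if their stability could be read as numbers rather than limits.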